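A few compounds are considered here, and "the series" means these few. Any claim that something is new, unique, unknown or untested is made for them only; others in the source may bear on it.

Measured so far:
compound 1 `[N-]=[N+]=Nc1nccc2ncn([C@H]3C[C@H](O)[C@@H](CO)O3)c12` — < 5%
compound 2 `CSc1nccc2c1ncn2C1O[C@H](CO)[C@@H](O)[C@H]1O` — < 5%

In a functional assay on EL4 cells (Mus musculus) for inhibition, tested at 100 uM (on this read-out higher numbers stand for more inhibition at the one concentration tested (going by the name of the read-out) and lower numbers for less inhibition), compound 1 gives < 5%, which is a limit of the assay and not a number. Compound 2 gives < 5% in this assay, likewise a limit. Compound 2 thus sits at the limit shared by both measured values (the limit of < 5% in this assay, at which 2 of the 2 values shown sit). Compound 3 `OC[C@H]1OC(n2cnc3c(S)nccc32)[C@H](O)[C@@H]1O` differs from compound 2 by hydrogen in place of methyl on a sulfur. Within the data shown here, no measured step between compounds is available, and the two limits give no direction to read from, so no step beyond the scatter is expected. Compound 3 is estimated at 3% in this assay, within 0% to 10%, most likely reported again as a limit. The expected step that the limit leaves unreadable from compound 2 to compound 3 is accordingly no change beyond the scatter.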

Compound 3, a percentage reported as inhibition, at one concentration (the size of the read-out at that concentration, not a potency): < 5%
Compound 3 was reported as a limit; the forecaster's own chance of this, stated with the estimate: 85%; the middle value does not contradict the limit.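

No step can be read from compound 2 to compound 3, since both values are limits and not numbers: the limit of < 5% in this assay, at which 3 of the 3 values shown sit.

The compounds shown leave open whether any change in this series gives readable inhibition.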